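A few compounds are considered here, and "the series" means these few. Any claim that something is new, unique, unknown or untested is made for them only; others in the source may bear on it.

Compound 1 `CCC1(OC(=O)N2CCC(Oc3ncnc(Oc4ccc(S(C)(=O)=O)nc4C)c3F)CC2)CC1` and compound 2 `Cc1nc(S(C)(=O)=O)ccc1Oc1ncnc(OC2CCN(C(=O)C(F)(F)F)CC2)c1F` share a core and differ only in the group attached to the carbonyl carbon on the ring nitrogen. In a functional assay on isolated protein for inhibition of Glucose-dependent insulinotropic receptor (Homo sapiens), read by HTRF and cAMP accumulation (a higher number here means that more compound is needed for the effect, a lower number that less compound is needed), compound 1 gives 22 nM, and compound 2 gives 151 nM; the step of a 6.9-fold higher number from compound 1 to compound 2 (0.84 log units; beyond the scatter) lies beyond the scatter. Compound 2 therefore stands as the higher of the two measured numbers, with compound 1 the nearest.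

Compound 3 `Cc1nc(S(C)(=O)=O)ccc1Oc1ncnc(OC2CCN(C(=O)C(C)(F)F)CC2)c1F` differs from compound 2 by methyl in place of fluoro on a saturated chain carbon bound to a carbonyl carbon and two fluorine atoms, so trifluoromethyl becomes 1,1-difluoroethyl. Among the measured compounds shown here, the only measured step that bears on this, a 6.9-fold higher number from compound 1 to compound 2 (0.84 log units; beyond the scatter), shows that a larger group on this carbonyl carbon went with a lower number, and compound 3 adds back one carbon. The expected step is therefore a 1.5-fold lower number from compound 2 to compound 3 (0.18 log units; within the scatter), a small improvement in this assay. The estimate for compound 3 is 100 nM, expected to fall between 40 nM and 250 nM.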

Compound 3, half-maximal effective concentration: 37 nM
Estimate against measurement, compound 3: 2.7-fold (0.43 log units) above, and the stated range ends above it.
By their numbers in this assay, from the lowest: compounds 1 and 3 (each within the scatter of the next); then compound 2.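

In this assay, replacing a single fluoro with methyl on this saturated chain carbon is enough on its own to move the number beyond the scatter (a 4.1-fold lower number from compound 2 to compound 3 (0.61 log units; beyond the scatter)), something the earlier step could not show, since it replaced the whole group on the carbonyl carbon. The 1,1-difluoroethyl group also brings the number to within the scatter of the larger group in compound 1 (a 1.7-fold higher number from compound 1 to compound 3 (0.23 log units; within the scatter)), so at this position the larger group is not needed to reach that level. Nothing measured here explains why this one-atom change matters.

The compounds shown leave open whether replacing a second fluoro with methyl would move the number further. They also leave open how a hydroxyl group, or a longer chain such as ethyl, would behave on this same carbon.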